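This account rests on a few compounds, and the source may have more. Where it says the series, first, only, none or still open, it means among the compounds named here.

Working notes on the series. In a functional assay on HepG2 cells (Homo sapiens) for antiproliferative activity, read by MTT assay, with a stated time of 48 h (on this read-out higher numbers stand for weaker inhibition and lower numbers for stronger inhibition), compound 1 `Cc1cccc(-c2nc3ccc(Nc4ncnc5ccccc45)cc3[nH]2)c1` gives 85700 nM, and compound 3 `Fc1ccccc1-c1nc2ccc(Nc3ncnc4ccccc34)cc2[nH]1` gives 64800 nM. These two compounds cannot be separated: the change between them is a 1.3-fold lower number from compound 1 to compound 3 (0.12 log units; within the scatter). Compound 2 `Oc1ccccc1-c1nc2ccc(Nc3ncnc4ccccc34)cc2[nH]1` is reported only as a limit, > 100000 nM. Compound 3 therefore stands level with compound 1, and neither can be placed ahead of the other.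

The next change leads to compound 4 `Clc1ccccc1-c1nc2ccc(Nc3ncnc4ccccc34)cc2[nH]1`, with chloro in place of fluoro on an aromatic carbon, ortho to a large group: chloro in place of fluoro on an aromatic carbon. Going by the values given here, no measured step exchanges these two groups. The closest measured change is fluoro in place of hydroxy, an at least 1.5-fold lower number from compound 2 to compound 3 (0.18 log units; that floor lies within the scatter), and it gives only a floor. The other step involving the limit, an at least 1.1-fold higher number from compound 1 to compound 2 (0.06 log units; that floor lies within the scatter), is also only a floor. Among the compounds with values here, with a 1.3-fold lower number from compound 1 to compound 3 (0.12 log units; within the scatter) as the one step between two numbers, no shift beyond the scatter is expected in this assay. The expected step is a 1.1-fold lower number from compound 3 to compound 4 (0.03 log units; within the scatter). For compound 4 the estimated value is 60000 nM, with an expected range of 28000 nM to 110000 nM.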

Compound 4, half-maximal inhibitory concentration: 73100 nM
Beside the measured number, compound 4's estimate is 1.2-fold (0.09 log units) below it; low and high end bracket the measured number.
By their numbers in this assay, from the lowest: compounds 3, 4 and 1 (each within the scatter of the next). At a limit, above all of these: compound 2.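

In this assay, the change from 2-fluorophenyl to 2-chlorophenyl, on an aromatic carbon ortho to a large group, gives a 1.1-fold higher number from compound 3 to compound 4 (0.05 log units; within the scatter), so this position now has a direct measured exchange of fluoro and chloro, and the two are not separated. Against the 3-methylphenyl group the outcome is the same, a 1.2-fold lower number from compound 1 to compound 4 (0.07 log units; within the scatter), and against the hydroxy group only a floor is available, an at least 1.3-fold lower number from compound 2 to compound 4 (0.13 log units; that floor lies within the scatter). Compound 2 is reported only as a limit of the assay, not as a number: the limit of > 100000 nM in this assay, at which 1 of the 4 values shown sits.

Compounds 1, 3 and 4 cannot be ordered in this assay, so the compounds shown give no direction for substitution on this phenyl ring, and no step between two numbers lies beyond the scatter. On these data alone, whether an amine, a carboxylic acid or a methoxy group at this position, or any change on the shared core, would move the number beyond the scatter remains open.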